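The source may report more compounds than this note shows. Statements on the series, on what has been measured and on what is new or still open speak of the compounds shown alone.

Measured so far:
- compound 1 `O=C(O)CCNC(=O)c1ccc(CN(c2ccc(Cl)cc2)c2nc(-c3ccc(C(F)(F)F)cc3)cs2)cc1`: 372 nM
- compound 2 `O=C(O)CCNC(=O)c1ccc(CN(c2ccc(C(F)(F)F)cc2)c2nc(-c3ccc(Cl)cc3)cs2)cc1`: 648 nM

In an assay on membranes from liver for binding affinity to Glucagon receptor (Mus musculus) (a lower number here means a stronger inhibitor, a higher number a weaker inhibitor), compound 1 gives 372 nM. Compound 2 gives 648 nM in this assay, a number that lies within the usual scatter of compound 1, so the two are not separable on these data. Compound 3 `O=C(O)CCNC(=O)c1ccc(CN(c2ccc3c(c2)CCC3)c2nc(-c3ccc(C(F)(F)F)cc3)cs2)cc1` differs from compound 1 by 2,3-dihydro-1H-inden-5-yl in place of 4-chlorophenyl on a nitrogen on an aromatic ring. For the measured compounds named here, no step between two measured compounds covers this change, so its effect is unknown. The step that this estimate means, a 1.3-fold higher number from compound 1 to compound 3 (0.13 log units; within the scatter), is expected to stay within the scatter, in no clear direction. Compound 3 is therefore expected to come in at 500 nM, between 150 nM and 1700 nM.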

Compound 3, half-maximal inhibitory concentration: 830 nM
For compound 3 the middle estimate is 1.7-fold (0.22 log units) below the measured one, and the stated range covers the measured number.
By their numbers in this assay, from the lowest: compounds 1, 2 and 3 (each within the scatter of the next, the first and the last beyond it).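

In this assay, for the compounds shown here, the change to 2,3-dihydro-1H-inden-5-yl in place of 4-chlorophenyl on a nitrogen on an aromatic ring gives a 2.2-fold higher number from compound 1 to compound 3 (0.35 log units; beyond the scatter), the first step at this position that can be read. The step is modest, so this place still tolerates a group with an added five-membered non-aromatic ring and no chlorine. Nothing measured here accounts for the step. The compounds shown leave open how a plain phenyl or a 4-methoxyphenyl group would read at this place, and so whether the loss of chlorine or the added ring carries the step.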